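Swapping an Aryl Ether for Cyclohexylmethyl on the Core

This account rests on a few compounds, and the source may have more. Where it says the series, first, only, none or still open, it means among the compounds named here.

Compound 1 `COc1ccccc1Oc1ccc2c(NCCCNCc3ccco3)ccnc2c1`: 9.28
Compound 2 `COc1cccc(Oc2ccc3c(NCCCNCc4cc(F)ccc4OC)ccnc3c2)c1`: 9.28
Compound 3 `COc1cccc(CNCCCNc2ccnc3cc(Cc4ccccc4)ccc23)c1O`: 9.47

In a physicochemical assay for acid dissociation, compound 1 gives 9.28. Compound 2 gives the same number at the digits shown, and compound 3 gives 9.47, which lies within the scatter of the measurement, so the three compounds cannot be told apart on this read-out. Compound 4 `c1coc(CNCCCNc2ccnc3cc(CC4CCCCC4)ccc23)c1` has not yet been measured. It differs from compound 1 in one place: cyclohexylmethyl in place of 2-methoxyphenoxy on an aromatic carbon. The change sits on the shared core, away from the chain that carries the dissociating group, and compound 3 carries a benzyl group at the same place without a shift beyond the scatter. The step of a number 0.12 log units higher from compound 1 to compound 4 (within the scatter) is therefore expected to stay within the scatter. Compound 4 is estimated at 9.4, with a range from 9.1 to 9.7.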

Compound 4, acid dissociation constant: 9.47
The estimate for compound 4 lay 0.07 log units below the measured number, within the range that was stated.
By their numbers in this assay, from the lowest: compounds 1, 2, 3 and 4 (each within the scatter of the next).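

In this assay, cyclohexylmethyl in place of 2-methoxyphenoxy on this aromatic carbon gives a number 0.19 log units higher from compound 1 to compound 4 (within the scatter), the only step shown that isolates a change in one place. The exchange of an aromatic ring carrying 2 hydrogen-bond acceptors for a non-aromatic ring carrying none therefore does not separate the two compounds on this read-out. Nothing available offers an explanation for this result. From the compounds shown here alone, it remains open whether an amine or a carboxylic acid on the same aromatic carbon would also stay within the scatter. Going by these compounds, a longer chain at this place is equally open.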